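Removing the methyl from the ester of a long-chain amide

This account rests on a few compounds, and the source may have more. Where it says the series, first, only, none or still open, it means among the compounds named here.

Measured so far, in an ADME assay on cells (Splenocyte, Mus musculus, strain BALB/c) for cytotoxicity, read by MTT assay, tested at 10 ug/mL; on this read-out higher numbers stand for a stronger effect at the one concentration tested and lower numbers for a weaker effect:
compound 1, `CCCCCCCCCCCCCCC(N)CO`, gives 20.2%
compound 2, `CCCCCCCCCCCCCCC(COCc1ccccc1)NC(=O)CCCC(=O)O`, gives 6.4%
compound 3, `CCCCCCCCCCCCCCC(CO)NC(=O)CCCC(=O)OC`, gives 18.9%

Compound 3 stands second highest of these three numbers; its nearest neighbour is compound 1, which lies within the scatter of it, while compound 2 lies furthest, beyond the scatter. The step from compound 3 to compound 4, `CCCCCCCCCCCCCCC(CO)NC(=O)CCCC(=O)O`, is hydrogen in place of methyl on an oxygen next to a carbonyl group. Within the data shown here, the one measured step, a number 1.3 percentage points lower from compound 1 to compound 3 (within the scatter), concerns a different place and was within the scatter. Among the measured compounds shown here, compound 2, which also carries a carboxy group but a benzyl ether in place of the hydroxy, gives the lowest value, yet it differs from compound 4 in two places, so no single measured step bears directly on this change. Compound 4 is therefore expected to move by a number 4.9 percentage points lower from compound 3 to compound 4 (within the scatter), leaning lower but not clearly beyond the scatter. Compound 4 is estimated at 14%, with a range from 4% to 26%.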

Compound 4, a percentage reported as activity, at one concentration (the size of the read-out at that concentration, not a potency): 14.5%
Compound 4: the middle estimate sits 0.5 percentage points below what was measured, and the stated range covers the measured number.
By their numbers in this assay, from the lowest: compounds 2, 4, 3 and 1 (each within the scatter of the next, the first and the last beyond it).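

In this assay, hydrogen in place of methyl on this oxygen gives a number 4.4 percentage points lower from compound 3 to compound 4 (within the scatter), so the free carboxy group and its methyl ester are not told apart here. The two neighbouring changes give no clear separation either: removing the benzyl gives a number 8.1 percentage points higher from compound 2 to compound 4 (within the scatter), and adding the (3-carboxypropyl)carbonyl on the amine nitrogen gives a number 5.7 percentage points lower from compound 1 to compound 4 (within the scatter). No measurement shown offers an explanation for these steps. Still open, on these data alone, is whether an ethyl ester or a primary amide in place of the carboxy group would give a step beyond the scatter.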